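Replacing a nitrile-bearing aryl group in a bombesin receptor agonist

The source may report more compounds than this note shows. Statements on the series, on what has been measured and on what is new or still open speak of the compounds shown alone.

Measured compounds:
compound 1 `CCCCc1cnc(Cc2ccc(-c3ccccc3C(=O)O)cc2)[nH]1`: > 10000 nM
compound 2 `N#Cc1ccc(Cc2cnc(CCc3ccc(-c4ccccc4C(=O)O)cc3)[nH]2)cc1`: 723 nM
compound 3 `CCCCc1cnc(C(CCCO)Cc2ccc(-c3ccccc3C(=O)O)cc2)[nH]1`: 238 nM

In an in vitro functional assay on cells for agonist activity at Bombesin receptor subtype-3 (Mus musculus), read by luminescence and calcium flux (a lower number here means that less compound is needed, a higher number that more compound is needed for the effect), compound 2 gives 723 nM, the higher of the two numbers recorded. Compound 3 gives 238 nM in this assay, a lower number that lies beyond the usual scatter. Compound 1 returns only a limit in this assay, (the limit of > 10000 nM in this assay, at which 1 of the 3 values shown sits), and not a number.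

Compound 4 `O=C(O)c1ccccc1-c1ccc(CCc2ncc(Cc3cccc(Cl)c3)[nH]2)cc1` is the next compound to be tested. Compared with compound 2 it carries 3-chlorophenyl in place of 4-cyanophenyl on a saturated chain carbon bound to an aromatic carbon. Going by the values given here, no measured pair shows this exchange, so the size of the step from compound 2 to compound 4 is unknown. The nitrile is the only hydrogen-bond acceptor that leaves, and the chlorine that enters brings none; the author expects the step of a 1.4-fold lower number from compound 2 to compound 4 (0.16 log units; within the scatter) to stay small, at most modestly beyond the scatter, with no firm direction. For compound 4 the estimated value is 500 nM, expected to fall between 150 nM and 2000 nM.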

Compound 4, half-maximal effective concentration: 31 nM
Estimate against measurement, compound 4: 16-fold (1.21 log units) above, and the stated range ends above it.
By their numbers in this assay, from the lowest: compound 4; then compound 3; then compound 2. At a limit, above all of these: compound 1.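

In this assay, going by these compounds alone, 3-chlorophenyl in place of 4-cyanophenyl on a saturated chain carbon bound to an aromatic carbon gives a 23-fold lower number from compound 2 to compound 4 (1.37 log units; beyond the scatter), which shows that the number depends strongly on this group, something the earlier compounds could not show in a single exchange. The nitrile, the only hydrogen-bond acceptor in the group that leaves, is not required for a low number here, as the 3-chlorophenyl of compound 4 has no such acceptor. Nothing measured here accounts for the size of this step.

The exchange changes both the substituent and its numbered ring location, so the compounds shown do not separate these two changes. As far as these compounds go, how a 3-cyanophenyl or a 4-chlorophenyl group would read at this place remains open.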